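Thiophene in place of chlorophenyl on the shared core

This account rests on a few compounds, and the source may have more. Where it says the series, first, only, none or still open, it means among the compounds named here.

Compound 3 `Cc1ccc2nc(Cl)c(/C=N/n3cc(-c4ccc(Cl)cc4)nc3N)cc2c1` gives only a limit in a functional assay on HCT-116 cells (Homo sapiens) for cytotoxicity, read by MTT assay, with a stated time of 48 h; a higher number here means a weaker inhibitor, a lower number a stronger inhibitor: compound 3 shows > 50000 nM, a limit of the assay and not a number. Compound 2 `Nc1nc(-c2ccc(Cl)cc2)cn1/N=C/c1cc2ccccc2nc1Cl` likewise reaches only a limit, > 50000 nM. Compound 1 `Nc1nc(-c2ccccc2)cn1/N=C/c1cc2ccccc2nc1Cl`, with plain phenyl, gives 6920 nM in this assay. The step of an at least 7.2-fold higher number from compound 1 to compound 2 (0.85 log units; beyond the scatter) is readable; the step that the two limits leave unreadable from compound 2 to compound 3 is not because of the limit of > 50000 nM in this assay, at which 2 of the 3 values shown sit.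

Compound 4 `Cc1ccc2nc(Cl)c(/C=N/n3cc(-c4cccs4)nc3N)cc2c1` differs from compound 3 by thiophen-2-yl in place of 4-chlorophenyl on an aromatic carbon. Within the data shown here, no measured step exchanges the aryl group itself, so the only guide is that compound 1 lacks the chloro that was added in an at least 7.2-fold higher number from compound 1 to compound 2 (0.85 log units; beyond the scatter), and compound 4 also lacks it. A gain of similar size is therefore expected, as an at least 2.5-fold lower number from compound 3 to compound 4 (0.39 log units; beyond the scatter). Compound 4 is estimated at 20000 nM, within 5000 nM to 60000 nM.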

Compound 4, half-maximal inhibitory concentration: 7710 nM
Compound 4: the middle estimate sits 2.6-fold (0.41 log units) above what was measured; low and high end bracket the measured number.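

At this aromatic carbon of the five-membered ring, exchanging the aryl group itself brings a readable number back on the methyl-bearing core: in this assay, thiophen-2-yl in place of 4-chlorophenyl gives an at least 6.4-fold lower number from compound 3 to compound 4 (0.81 log units; beyond the scatter). Earlier compounds showed only the chloro step on the phenyl ring at this position, not a change of the ring. The true size of the new step stays open because compound 3 gives a limit and not a number: the limit of > 50000 nM in this assay, at which 2 of the 4 values shown sit.

The effect of the methyl on the shared core remains unreadable. From the compounds shown here alone, how an amine or a carboxylic acid at this carbon would read in this assay also remains open.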